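This account rests on a few compounds, and the source may have more. Where it says the series, first, only, none or still open, it means among the compounds named here.

Compound 1 `CC(=O)N[C@@H]1CCN(c2cc(C)nn3c(-c4ccc(C(F)(F)F)cc4)c(C)nc23)C1`: > 95%
Compound 2 `COc1ccc(-c2c(C)nc3c(N4CC[C@@H](NC(C)=O)C4)cc(C)nn23)cn1`: > 95%
Compound 3 `COc1ccc(-c2c(C)nc3c(N4CC[C@@H](NC(=O)COc5ccccc5)C4)cc(C)nn23)cc1OC`: > 95%

All three entries come from an ADME assay on microsomes from liver (Mus musculus) for metabolic stability, read by LC-MS, with NADPH named in the record, with a stated time of 60 min, tested at 1 uM, in the absence of a further agent (a lower number here means that less of the compound is left, a higher number that more of the compound is left), and each is a limit, not a number. The evidence so far is the limit of > 95% in this assay, at which 3 of the 3 values shown sit. Compound 3 reads > 95%, which is only a limit, so its exact place in the series cannot be read.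

Going from compound 3 to compound 4 `COc1ccc(-c2c(C)nc3c(N4CC[C@@H](NC(=O)Oc5ccc6ccccc6c5)C4)cc(C)nn23)cc1OC`, one group changes: (naphthalen-2-yl)oxy in place of phenoxymethyl on a carbonyl carbon. Put simply, (naphthalen-2-yl)oxy stands in place of phenoxymethyl on a carbonyl carbon.

Within the data shown here, the only measured step is a step that the two limits leave unreadable from compound 1 to compound 2. It lies on an aromatic carbon rather than on a carbonyl carbon, and it offers no size to carry over. The expectation therefore rests on compound 3 and its limit of > 95%.

In this assay, no step beyond the scatter is expected, and any step that does appear is expected to be a fall. The expected step is a number at least 5 percentage points lower from compound 3 to compound 4 (that floor lies within the scatter). For compound 4 the estimate is 90%, with an expected range from 60% to 100%.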

Compound 4, percent of the compound remaining: > 95%
Compound 4 gave a limit, no number; the forecaster's own chance of this, stated with the estimate: 55%; middle value at least 5 percentage points from the limit.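

Compound 3 and compound 4 each give only a limit, not a number, so no step can be read for (naphthalen-2-yl)oxy in place of phenoxymethyl. The compounds shown leave open how far compounds 1 to 4 truly differ in this assay, and which change would lower the amount remaining.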